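The source may report more compounds than this note shows. Statements on the series, on what has been measured and on what is new or still open speak of the compounds shown alone.

Of the compounds shown here, three built on one shared core have so far been measured in a functional assay on HEK293 cells for agonist activity at Bombesin receptor subtype-3 (Homo sapiens), read by luminescence and calcium flux, with a stated time of 10 min; on this read-out higher numbers stand for an effect only at larger amounts of compound and lower numbers for an effect already at smaller amounts. Compound 1 `CCC(C)(C)Cc1c[nH]c(CCc2ccc(-c3cccc(C)n3)cc2)n1` gives 105 nM. Compound 2 `CCC(C)(C)Cc1c[nH]c(CCc2ccc(-n3cccn3)cc2)n1` gives 135 nM, and compound 3 `CCC(C)(C)Cc1c[nH]c(CCc2ccc(-c3cccc(C#N)n3)cc2)n1` gives 193 nM. The step of a 1.8-fold higher number from compound 1 to compound 3 (0.26 log units; within the scatter) and the step of a 1.4-fold higher number from compound 2 to compound 3 (0.16 log units; within the scatter) both lie within the scatter, so compound 3 stands alongside the other two rather than apart from them. Compound 4 `CCC(C)(C)Cc1c[nH]c(CCc2ccc(-c3cnsc3)cc2)n1` carries 1,2-thiazol-4-yl in place of 6-cyanopyridin-2-yl on an aromatic carbon. Among the compounds with values here, two measured steps bear on this exchange of a six-membered aromatic ring for a five-membered one: a 1.3-fold higher number from compound 1 to compound 2 (0.11 log units; within the scatter) and a 1.4-fold higher number from compound 2 to compound 3 (0.16 log units; within the scatter); neither left the scatter. A step no larger than the scatter is therefore expected in either direction, giving a 1.2-fold lower number from compound 3 to compound 4 (0.08 log units; within the scatter). Compound 4 is estimated at 160 nM, within 65 nM to 400 nM.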

Compound 4, half-maximal effective concentration: 44 nM
Estimate against measurement, compound 4: 3.6-fold (0.56 log units) above; measured number outside the range, below it.
By their numbers in this assay, from the lowest: compound 4; then compounds 1, 2 and 3 (each within the scatter of the next).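

At this position, on an aromatic carbon para to a large group, 1,2-thiazol-4-yl separates from all three earlier groups, which had stayed within the scatter of one another (a 4.4-fold lower number from compound 3 to compound 4 (0.64 log units; beyond the scatter); a 2.4-fold lower number from compound 1 to compound 4 (0.38 log units; beyond the scatter)). A five-membered aromatic ring alone does not account for this, since compound 2 also carries one, in 1H-pyrazol-1-yl (a 3.1-fold lower number from compound 2 to compound 4 (0.49 log units; beyond the scatter)). No measurement shown explains the difference.

From the compounds shown here alone, it remains open whether a thiophen-3-yl or 1,2-oxazol-4-yl group would give a number like that of compound 4. Also open, going by these compounds, is how an amine or a methyl on the 1,2-thiazol-4-yl ring would fare.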